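From Fluoro to Methoxy on the Aromatic Ring

The source may hold more compounds than are shown below. What is called first, only, known or untested is meant among the compounds shown, and "the series" means these compounds.

In a functional assay on NCI-H157 cells (Homo sapiens) for antiproliferative activity, read by sulforhodamine B assay, with a stated time of 48 h, tested at 0.1 uM (a higher number here means more inhibition of growth at the concentration tested, a lower number less inhibition of growth), compound 1 `Cc1occc1-c1nn2c(-c3ccncc3)nnc2s1` gives 47.1% and compound 2 `Fc1ccc(OCc2nn3c(-c4ccncc4)nnc3s2)cc1` gives 21.3% as the lower of the two numbers, a gap beyond the usual scatter. Compound 3 `COc1ccc(OCc2nn3c(-c4ccncc4)nnc3s2)cc1` differs from compound 2 by methoxy in place of fluoro on an aromatic carbon with methoxy in place of fluoro on an aromatic carbon, 4-fluorophenyl to 4-methoxyphenyl. Within the data shown here, no measured pair shows this change, so in this assay no step beyond the scatter is expected in either direction. The estimated a number 3.7 percentage points higher from compound 2 to compound 3 (within the scatter) stays within that scatter. For compound 3 the expected value is 25% within an estimated range from 10% to 45% for this single concentration.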

Compound 3, percent growth inhibition at one concentration: 57.2%
Beside the measured number, compound 3's estimate is 32.2 percentage points below it, and the stated range ends below it.
By their numbers in this assay, from the lowest: compound 2; then compound 1; then compound 3.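

In this assay, the aromatic carbon para to a large group proves sensitive to what it carries: methoxy in place of fluoro gives a number 35.9 percentage points higher from compound 2 to compound 3 (beyond the scatter) at this single concentration. This is the first step shown between two compounds that differ in one place, and it is large. Nothing available bears on why the number moves this far. As far as these compounds go, what an amine, a carboxylic acid or a longer ethoxy chain would do on the same carbon stays open. So does whether the step holds at other concentrations.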